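The source may report more compounds than this note shows. Statements on the series, on what has been measured and on what is new or still open speak of the compounds shown alone.

- Compound 1 `O=S(=O)(/C=C/c1ccc(Br)cc1)Cc1ccc(Nc2ncnc3ccccc23)cc1` gives 55000 nM
- Compound 2 `O=S(=O)(/C=C/c1ccc(Br)cc1)Cc1ccc(Nc2ncnc3ccc(Br)cc23)cc1` gives 3000 nM

In a functional assay on DU-145 cells (Homo sapiens) for inhibition (on this read-out lower numbers stand for stronger inhibition of growth and higher numbers for weaker inhibition of growth), compound 2 has the lower of the two numbers, so it is the stronger growth inhibitor of this pair. Compound 3 `O=S(=O)(/C=C/c1ccc(Cl)cc1Cl)Cc1ccc(Nc2ncnc3ccc(Br)cc23)cc1` differs from compound 2 in one group: 2,4-dichlorophenyl in place of 4-bromophenyl on a double-bonded chain carbon bound to a double-bonded chain carbon. For the measured compounds named here, the only measured step of an 18-fold lower number from compound 1 to compound 2 (1.26 log units; beyond the scatter) was large but concerns a bromo in place of hydrogen on an aromatic carbon, and compound 3 keeps that bromo. Going by the values given here, no measured step covers the group exchanged here, so compound 3 is expected to stay close to compound 2 at 3000 nM with no shift beyond the scatter. The estimated step is no change at the digits printed from compound 2 to compound 3 (within the scatter) with wide uncertainty. For compound 3 the estimated value is 3000 nM within an expected range of 800 nM to 11000 nM in this assay.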

Compound 3, concentration for 50% growth inhibition: 2000 nM
Compound 3: middle estimate off by 1.5-fold (0.18 log units), on the high side; the range from low to high includes it.
By their numbers in this assay, from the lowest: compounds 3 and 2 (each within the scatter of the next); then compound 1.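

Swapping 4-bromophenyl for 2,4-dichlorophenyl on the double-bonded chain carbon gives a 1.5-fold lower number from compound 2 to compound 3 (0.18 log units; within the scatter) in this assay, so this position tolerates the exchange without a shift that stands clear of the scatter. For the compounds shown here, the earlier step concerned only the bromo on the shared core, so this is the first reading of a change to the group on the chain. Nothing available explains why the two groups read alike. Still open, from the compounds shown here alone, is whether a quite different group here, such as an amine or a carboxylic acid, would keep this level. Going by these compounds, it is also open whether 2,4-dichlorophenyl would read the same on the core of compound 1.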